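The compounds below may be only part of what the source reports. "The series", "measured", "known", "first", "only" and "open" are said of these compounds alone.

Three compounds share one core and differ only in the group on the double-bonded chain: compound 1 `Cc1ccc(/C=C/C(=O)c2cccc(NC(=O)c3cc(-c4ccncc4)n[nH]3)c2)cc1` carries 4-methylphenyl, compound 2 `O=C(/C=C/c1ccco1)c1cccc(NC(=O)c2cc(-c3ccncc3)n[nH]2)c1` carries furan-2-yl, and compound 3 `O=C(/C=C/c1ccccc1Cl)c1cccc(NC(=O)c2cc(-c3ccncc3)n[nH]2)c1` carries 2-chlorophenyl. In a functional assay, read by spectrophotometry, tested at 100 uM (on this read-out lower numbers stand for stronger inhibition and higher numbers for weaker inhibition), compound 1 gives 64600 nM in this test, compound 2 gives 72300 nM in this test, and compound 3 gives 79800 nM in this test. Compound 3 therefore stands level with the other two, within the scatter of both.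

Compound 4 `COc1ccccc1/C=C/C(=O)c1cccc(NC(=O)c2cc(-c3ccncc3)n[nH]2)c1` keeps all of compound 3 except one group: methoxy in place of chloro on an aromatic carbon in words, methoxy in place of chloro on an aromatic carbon, ortho to a large group. For the measured compounds named here, no measured pair makes this exact swap. The closest evidence comes from exchanging the whole group on the chain, which gave a 1.1-fold higher number from compound 1 to compound 2 (0.05 log units; within the scatter) as one step, a 1.2-fold higher number from compound 1 to compound 3 (0.09 log units; within the scatter) as another and a 1.1-fold higher number from compound 2 to compound 3 (0.04 log units; within the scatter) as the third. All three stay within the scatter, so no step beyond the scatter is expected in this assay for this change, and no direction is favoured with any confidence. The estimate is a 1.1-fold lower number from compound 3 to compound 4 (0.03 log units; within the scatter) as the expected step. Compound 4 is expected at 75000 nM as an estimate, with a likely range from 48000 nM to 110000 nM in this test.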

Compound 4, half-maximal inhibitory concentration: 56700 nM
For compound 4 the middle estimate is 1.3-fold (0.12 log units) above the measured one; the range from low to high includes it.
By their numbers in this assay, from the lowest: compounds 4, 1, 2 and 3 (each within the scatter of the next).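

Replacing chloro with methoxy on this aromatic carbon, ortho to a large group, gives a 1.4-fold lower number from compound 3 to compound 4 (0.15 log units; within the scatter) in this assay, so this place does not tell the two groups apart, even though methoxy has 1 hydrogen-bond acceptor and chloro has 0. For the compounds shown here, the wider exchanges of the whole group on the chain read the same way: 2-methoxyphenyl in place of furan-2-yl gives a 1.3-fold lower number from compound 2 to compound 4 (0.11 log units; within the scatter) and 2-methoxyphenyl in place of 4-methylphenyl gives a 1.1-fold lower number from compound 1 to compound 4 (0.06 log units; within the scatter) and, with the earlier steps, this places all four compounds level with one another, so the new group adds no measurable difference to the series. No measurement is available that could explain this result.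

From the compounds shown here alone, it remains open whether a group of another kind at this place, such as an amine or a carboxylic acid, would produce a step beyond the scatter. Going by these compounds, it is also open whether a change to the shared core, rather than to the group on the chain, would move the number further than any of the exchanges seen here.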